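A few compounds are considered here, and "the series" means these few. Any claim that something is new, unique, unknown or untested is made for them only; others in the source may bear on it.

Of the compounds shown here, three have been measured in a functional assay on PC-3 cells (Homo sapiens) for inhibition, read by sulforhodamine B assay, with a stated time of 48 h; a lower number here means a stronger inhibitor of growth, a higher number a weaker inhibitor of growth. Compound 1 `COc1ccc(-c2ccc(-c3ccc(C(=N)N)o3)o2)cc1` gives 1880 nM, compound 2 `N=C(N)c1ccc(-c2ccc(-c3cncc4ccccc34)s2)s1` gives 1560 nM, and compound 3 `COc1cc(OC)cc(-c2ccc(-c3ccc(C(=N)N)o3)o2)c1` gives 4770 nM. Compound 1 therefore sits between the other two: its number and that of compound 2 lie within the usual scatter of each other, while compound 3, which carries two methoxy groups, sits at a higher number beyond the scatter.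

Compound 4 `N=C(N)c1ccc(-c2ccc(-c3ccccc3)o2)o1` differs from compound 1 in one place: hydrogen in place of methoxy on an aromatic carbon. Among the measured compounds shown here, no measured pair shows this change, so its effect can only be guessed. The step of a 1.3-fold lower number from compound 1 to compound 4 (0.10 log units; within the scatter) is expected to be small, leaning toward a lower number but not clearly beyond the scatter. Compound 4 is thus expected to give about 1500 nM, somewhere between 600 nM and 4000 nM.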

Compound 4, concentration for 50% growth inhibition: 2640 nM
Beside the measured number, compound 4's estimate is 1.8-fold (0.25 log units) below it, within the range that was stated.
By their numbers in this assay, from the lowest: compounds 2, 1, 4 and 3 (each within the scatter of the next, the first and the last beyond it).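

Replacing methoxy with hydrogen on this aromatic carbon, para to a large group, gives in this assay the step of a 1.4-fold higher number from compound 1 to compound 4 (0.15 log units; within the scatter) and so leaves the two compounds indistinguishable. Among the compounds shown here, this is the first measured pair for this change, and it shows that growth inhibition here does not depend on keeping the methoxy group at this position. Nothing measured here explains this result. Going by these compounds, whether an amine or a carboxylic acid at this position would shift the number beyond the scatter remains open. Also open, on these data alone, is whether the same change behaves alike on other cores.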